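Compound 1 to compound 3: hydrogen in place of methyl

The compounds below may be only part of what the source reports. "The series", "measured", "known", "first", "only" and "open" are said of these compounds alone.

In a functional assay on DWD cells (Homo sapiens) for inhibition, read by sulforhodamine B assay (on this read-out lower numbers stand for stronger inhibition of growth and higher numbers for weaker inhibition of growth), compound 1 `Cc1ccc2[nH]c(-c3ccc(-c4ccc(-c5cccc(Cl)c5)cc4)cc3)nc2c1` gives 2510 nM and compound 2 `COc1ccc(-c2ccc(-c3ccc(-c4nc5cc(C)ccc5[nH]4)cc3)cc2)cc1OC` gives 1720 nM. Going by the values given here, these are the only two numbers so far, and they lie within the scatter of each other, so compound 1 has only that one close neighbour and no wider range to be placed in.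

Compound 3 `Clc1cccc(-c2ccc(-c3ccc(-c4nc5ccccc5[nH]4)cc3)cc2)c1` differs from compound 1 at a single place: hydrogen in place of methyl on an aromatic carbon. This is hydrogen in place of methyl on an aromatic carbon, in a six-membered aromatic ring of carbon only that is part of a fused or bridged system of two rings.

One measured step is available, a 1.5-fold lower number from compound 1 to compound 2 (0.16 log units; within the scatter). It lies within the scatter, but it concerns 3,4-dimethoxyphenyl in place of 3-chlorophenyl, so it bears only indirectly. Among the compounds with values here, no measured step tests the methyl itself. With nothing pointing either way, no direction is expected in this assay. The expected step is a 1.0-fold lower number from compound 1 to compound 3 (0.02 log units; within the scatter), which would stay within the scatter. For compound 3 the estimated value is 2400 nM, with an expected range of 1000 nM to 5500 nM.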

Compound 3, concentration for 50% growth inhibition: 100000 nM
Estimate against measurement, compound 3: 42-fold (1.62 log units) below, outside the stated range (above it).
By their numbers in this assay, from the lowest: compounds 2 and 1 (each within the scatter of the next); then compound 3.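

In this assay, the step of a 40-fold higher number from compound 1 to compound 3 (1.60 log units; beyond the scatter) shows that this aromatic carbon is highly sensitive to substitution: exchanging methyl, with its 1 heavy atom, for hydrogen gives a large step toward weaker inhibition of growth. The earlier pair showed no such sensitivity, since the step of a 1.5-fold lower number from compound 1 to compound 2 (0.16 log units; within the scatter) stays within the scatter, although it replaces 3-chlorophenyl with 3,4-dimethoxyphenyl elsewhere in the molecule and both of those compounds carry the methyl. No supporting measurement is available to explain the size of this step.

Open, on these data alone, is whether ethyl, methoxy, chlorine or an amine on this same carbon would keep the level of compound 1, lose it as hydrogen does, or go beyond it. This single pair also leaves open whether exchanging methyl for hydrogen would produce a step of similar size with the 3,4-dimethoxyphenyl group of compound 2 in place of the 3-chlorophenyl group.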